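Shifting a Methoxy Group Around an Aromatic Ring

The compounds below may be only part of what the source reports. "The series", "measured", "known", "first", "only" and "open" are said of these compounds alone.

Compound 1 `COc1ccccc1-n1cc(COc2ccc3c(c2)CCC3)nn1` carries a 2-methoxyphenyl group on a ring nitrogen of its shared core. Among the measured compounds shown here, in an ADME assay on HEK293 cells (Homo sapiens) for inhibition, read by MTT assay, with a stated time of 48 h, tested at 25 uM (on this read-out lower numbers stand for less inhibition and higher numbers for more inhibition at the one concentration tested (going by the name of the read-out)), compound 1 gives 19.8%, the only single number available. Two relatives were also prepared: compound 2 `CCc1ccc(NC(=O)Cn2cc(COc3ccc4c(c3)CCC4)nn2)cc1`, for which this assay returned "not determined" (no result reported), and compound 3 `Cc1cc([N+](=O)[O-])ccc1NC(=O)Cn1cc(COc2ccc3c(c2)CCC3)nn1`, for which this assay returned "not determined" (no result reported). So compound 1 stands alone as the one reference point, with nothing to compare it against.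

Compound 4 `COc1ccc(-n2cc(COc3ccc4c(c3)CCC4)nn2)cc1` keeps every atom of compound 1 but rearranges one group: 4-methoxyphenyl in place of 2-methoxyphenyl on an aromatic nitrogen. The methoxy substituent simply sits at a different position on the same aromatic ring.

For the measured compounds named here, with no measured pair showing how such a shift plays out, there is no basis for expecting a large move in either direction. The most reasonable expectation is that the step of a number 2.2 percentage points higher from compound 1 to compound 4 (within the scatter) stays within the usual scatter of this assay. On that footing, compound 4 is expected to give about 22% in this assay, with a plausible range from 8% to 38%.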

Compound 4, a percentage reported as inhibition, at one concentration (the size of the read-out at that concentration, not a potency): 21.1%
For compound 4 the middle estimate is 0.9 percentage points above the measured one, within the range that was stated.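

Among the compounds shown here, compound 1 and compound 4 form the first measured pair, and they differ only in where the methoxy group sits on the aromatic ring: 4-methoxyphenyl replaces 2-methoxyphenyl on an aromatic nitrogen of the shared core. In this assay this rearrangement gives a number 1.3 percentage points higher from compound 1 to compound 4 (within the scatter) and so the two compounds cannot be told apart on this read-out, which means that for this pair the place of the methoxy group on the ring makes no visible difference at the one concentration tested. Nothing available here explains why the two compounds read alike.

This single pair says only that one methoxy shift on this ring leaves the reading within the usual scatter, and it gives no guide to a different kind of group on the same aromatic nitrogen. From the compounds shown here alone, whether an amine or a carboxylic acid on this ring, or a longer chain such as butoxy in place of the methoxy group, would read the same as compound 1 and compound 4 remains open.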